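A Double Bond Enters the Ether Chain of Compound 2

This account rests on a few compounds, and the source may have more. Where it says the series, first, only, none or still open, it means among the compounds named here.

Of the compounds shown here, three have been tested in a functional assay on A2780 cells (Homo sapiens) for antiproliferative activity, read by MTT assay, with a stated time of 3 days; on this read-out lower numbers stand for stronger inhibition and higher numbers for weaker inhibition. Compound 1 `CCCCCCCCCCCCCCCCCCOC1(c2ccc(Br)cc2)SC=C(C)n2c1noc2=O` reaches only the limit of the measurement, > 100000 nM. Compound 2 `CCCCCOC1(c2ccc(Cl)cc2)SC=C(C)n2c1noc2=O` likewise stops at a limit, > 100000 nM. Compound 3 `CC1=CSC(O)(c2cccc(C(F)(F)F)c2)c2noc(=O)n21` gives an actual number, 60000 nM. Two of the three results thus sit at the limit of > 100000 nM in this assay, at which 2 of the 3 values shown sit, and compound 2 stands among them, showing no measurable inhibition. Compound 4 `CC/C=C/COC1(c2ccc(Cl)cc2)SC=C(C)n2c1noc2=O` differs from compound 2 by but-1-en-1-yl in place of butyl on a saturated chain carbon bound to an oxygen on a saturated carbon, a swap of a saturated chain for one carrying a double bond. Among the measured compounds shown here, with no measured step of this kind to go by, the expected step from compound 2 to compound 4 a step that the limit leaves unreadable from compound 2 to compound 4 is none beyond the scatter. Compound 4 is estimated at 150000 nM, within 50000 nM to 500000 nM, most likely again reported only as a limit.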

Compound 4, half-maximal inhibitory concentration: 55000 nM
Compound 4: middle estimate off by 2.7-fold (0.44 log units), on the high side; measured number inside the range.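

Among the ethers shown, a readable number in this assay appears only with the double bond in the chain, and pentyl to pent-2-en-1-yl reads as an at least 1.8-fold lower number from compound 2 to compound 4 (0.25 log units; that floor lies within the scatter) at this position. That floor alone does not separate the two compounds, and the true size of the step cannot be read because compound 2 rests on a limit: the limit of > 100000 nM in this assay, at which 2 of the 4 values shown sit.

On these data alone, whether the number would fall further with a shorter chain, a benzyl group or an amine in this place stays open. Also open, as far as these compounds go, is whether the double bond would have the same effect in a longer chain.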